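Aminothienopyridine ketones: nitro to bromo on the aryl ring

The source may hold more compounds than are shown below. What is called first, only, known or untested is meant among the compounds shown, and "the series" means these compounds.

Measured compounds:
compound 1, `CCC(=O)c1sc2nc(-c3cccs3)ccc2c1N`, 0.89 ug/mL
compound 2, `Nc1c(C(=O)c2cccc([N+](=O)[O-])c2)sc2nc(-c3cccs3)ccc12`, 0.15 ug/mL

For the measured compounds named here, in a functional assay on WI-38 VA13 cells (Homo sapiens) for cytotoxicity (a lower number here means that less compound is needed, a higher number that more compound is needed for the effect), compound 2 gives 0.15 ug/mL, the lower of the two numbers so far; compound 1, which carries a propanoyl group in place of the aroyl group on the shared core, gives 0.89 ug/mL in this assay, a higher number that lies beyond the scatter. How much of that gap comes from the aryl ring itself and how much from the nitro group on it cannot be separated from these two values.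

Compound 3, `Nc1c(C(=O)c2cccc(Br)c2)sc2nc(-c3cccs3)ccc12`, keeps the aroyl ring of compound 2 and differs from it in one place: bromo in place of nitro on an aromatic carbon, the bromo standing on an aromatic carbon of a six-membered aromatic ring of carbon only, meta to a large group. Going by the values given here, no comparable pair has been measured, so the size of this step is open. Bromo is a single heavy atom without hydrogen-bond acceptors; the expectation is a modest rise in this assay, a 2.7-fold higher number from compound 2 to compound 3 (0.43 log units; beyond the scatter), rather than none, with the possibility that the change stays within the scatter.

The value expected for compound 3 in this assay is 0.4 ug/mL, with a range from 0.12 ug/mL to 1.3 ug/mL.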

Compound 3, half-maximal effective concentration: 0.5 ug/mL
Compound 3: middle estimate off by 1.3-fold (0.10 log units), on the low side; the measured number falls inside the stated range.
By their numbers in this assay, from the lowest: compound 2; then compounds 3 and 1 (each within the scatter of the next).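

Working from the aroyl series, the substituent on this aromatic carbon, meta to a large group, matters: in this assay, bromo in place of nitro gives a 3.3-fold higher number from compound 2 to compound 3 (0.52 log units; beyond the scatter), a step beyond the scatter. The comparison with the propanoyl compound adds a second point, as 3-bromophenyl in place of ethyl on a carbonyl carbon gives a 1.8-fold lower number from compound 1 to compound 3 (0.25 log units; within the scatter), within the scatter, so an aryl ring on the carbonyl does not by itself set a number apart from that of compound 1, and the low number of compound 2 appears only with nitro on the ring. The data available offer no measurement that accounts for the difference between nitro and bromo at this place.

Going by these compounds, whether the low number of compound 2 is particular to nitro, or whether other groups on the same aromatic carbon would share it, remains open. A hydrogen, an amine or a nitrile at this place would show how far the numbers in this assay follow the group there, and a longer chain on the carbonyl carbon would extend the comparison with compound 1.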